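Acetamido for cyano on two fluorophenyl cores

The source may report more compounds than this note shows. Statements on the series, on what has been measured and on what is new or still open speak of the compounds shown alone.

Three compounds have been measured in a functional assay on HepG2 cells (Homo sapiens) for cytotoxicity, read by MTT assay, with a stated time of 24 h; on this read-out higher numbers stand for weaker inhibition and lower numbers for stronger inhibition:
compound 1, `N#Cc1ccc(S(=O)(=O)N2C/C(=C\c3ccccc3F)C(=O)/C(=C/c3ccccc3F)C2)cc1`, gives 16500 nM;
compound 2, `CC(=O)Nc1ccc(S(=O)(=O)N2C/C(=C\c3ccccc3F)C(=O)/C(=C/c3ccccc3F)C2)cc1`, gives 5200 nM;
compound 3, `N#Cc1ccc(S(=O)(=O)N2C/C(=C\c3cccc(F)c3)C(=O)/C(=C/c3cccc(F)c3)C2)cc1`, gives 2600 nM.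

Compound 4, `CC(=O)Nc1ccc(S(=O)(=O)N2C/C(=C\c3cccc(F)c3)C(=O)/C(=C/c3cccc(F)c3)C2)cc1`, is not yet measured. It differs from compound 3 in one place: acetamido in place of cyano on an aromatic carbon. The same change, in the same place, leads from compound 1 to compound 2: acetamido in place of cyano on an aromatic carbon. That measured step is a 3.2-fold lower number from compound 1 to compound 2 (0.50 log units; beyond the scatter). How the core of compound 3 differs from the core of compound 1 is not broken down here; the two values show compound 3 at the lower number, beyond the scatter, while compound 3 and compound 2 lie within the scatter of each other.

Going by the values given here, compound 4 is expected to follow with a 2.9-fold lower number from compound 3 to compound 4 (0.46 log units; beyond the scatter), resting on the earlier step of a 3.2-fold lower number from compound 1 to compound 2 (0.50 log units; beyond the scatter), which is the only example of this change measured so far. Compound 4 is therefore estimated at 900 nM, most likely between 350 nM and 2600 nM.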

Compound 4, half-maximal inhibitory concentration: 11100 nM
Compound 4: middle estimate off by 12-fold (1.09 log units), on the low side; the measured number lies above the stated range.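

In this assay the new step is a 4.3-fold higher number from compound 3 to compound 4 (0.63 log units; beyond the scatter), so acetamido in place of cyano does not carry over from the core of compound 1 to the core of compound 3. Set beside the earlier step, the direction reverses: the same change on two cores in this assay, a 3.2-fold lower number (0.50 log units; beyond the scatter) from compound 1 to compound 2 and a 4.3-fold higher number (0.63 log units; beyond the scatter) from compound 3 to compound 4, 14-fold (1.13 log units) apart, beyond the scatter of two such steps. Going by these compounds alone, this shows that, in these two pairs, the outcome of the change depends on the core; it does not show which difference between the two cores is responsible, and it rests on only two pairs.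

The compounds shown leave open how other groups in this place, such as an amine or a carboxylic acid, would behave on either core. They also leave open whether the same change on a third core would follow either step or neither.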